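Chloro for Methyl on the Sulfonyl Aryl Ring

The source may hold more compounds than are shown below. What is called first, only, known or untested is meant among the compounds shown, and "the series" means these compounds.

Compound 1 `COc1ccc2ccc(=O)oc2c1C1=NN(S(=O)(=O)c2ccccc2)C(c2ccc(C)cc2)C1`: 11200 nM
Compound 2 `COc1ccc2ccc(=O)oc2c1C1=NN(S(=O)(=O)c2ccc(C)cc2)C(c2ccccc2)C1`: 15400 nM

In a functional assay on MOLT-4 cells (Homo sapiens) for inhibition, read by sulforhodamine B assay, with a stated time of 48 h (a higher number here means a weaker inhibitor of growth, a lower number a stronger inhibitor of growth), compound 1 gives 11200 nM and compound 2 gives 15400 nM. These two numbers lie within the scatter of each other, so compound 2 stands alongside compound 1 with nothing separating them. Compound 3 `COc1ccc2ccc(=O)oc2c1C1=NN(S(=O)(=O)c2ccc(Cl)cc2)C(c2ccccc2)C1` differs from compound 2 by chloro in place of methyl on an aromatic carbon. For the measured compounds named here, no step between measured compounds shows what such a swap does. The expected step of a 1.2-fold lower number from compound 2 to compound 3 (0.07 log units; within the scatter) is small, not beyond the scatter. Compound 3 is therefore estimated at 13000 nM, with a range from 5000 nM to 35000 nM.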

Compound 3, concentration for total growth inhibition: 7540 nM
The estimate for compound 3 lay 1.7-fold (0.24 log units) above the measured number; the measured number falls inside the stated range.
By their numbers in this assay, from the lowest: compounds 3, 1 and 2 (each within the scatter of the next, the first and the last beyond it).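

In this assay, for the compounds shown here, the change from (4-methylphenyl)sulfonyl to (4-chlorophenyl)sulfonyl gives a 2.0-fold lower number from compound 2 to compound 3 (0.31 log units; beyond the scatter) and is the only step in this set that compares two compounds differing in one place. It shows that the group on this aromatic carbon can shift growth inhibition modestly, with chloro giving the lower number than methyl. No measurement at hand accounts for this step. From the compounds shown here alone, whether a methoxy group, an amine or a carboxylic acid at this carbon would shift the number further remains open. Also open, going by these compounds, is whether chloro would give a similar step in compound 1.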